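Permeability notes: diaryl ether variant of compound 1

This account rests on a few compounds, and the source may have more. Where it says the series, first, only, none or still open, it means among the compounds named here.

Compound 1 `COc1ccc(F)cc1CNCCCNc1ccnc2cc(Cc3cc(C)cc(C)c3)ccc12` stands lowest of the two numbers in an ADME assay for permeability, using PAMPA, with a stated time of 30 min, at pH 7.4 (on this read-out higher numbers stand for higher permeability and lower numbers for lower permeability), giving 23 10^-6 cm/s. Compound 2 `c1ccc(-c2ccc3c(NCCCNCc4ccco4)ccnc3c2)cc1` gives 237 10^-6 cm/s in this assay, a difference beyond the usual scatter. Compound 3 `COc1cccc(Oc2ccc3c(NCCCNCc4cc(F)ccc4OC)ccnc3c2)c1` has not yet been measured. It differs from compound 1 by 3-methoxyphenoxy in place of 3,5-dimethylbenzyl on an aromatic carbon. Going by the values given here, no measured pair covers this change, so the size of the step is uncertain. A modest decrease in this assay is expected for compound 3, with the step of a 1.5-fold lower number from compound 1 to compound 3 (0.19 log units; within the scatter) likely to stay near the edge of the scatter. Compound 3 is estimated at 15 10^-6 cm/s, within a range of 5 10^-6 cm/s to 45 10^-6 cm/s.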

Compound 3, apparent permeability: 317 10^-6 cm/s
For compound 3 the middle estimate is 21-fold (1.32 log units) below the measured one, outside the stated range (above it).
By their numbers in this assay, from the lowest: compound 1; then compounds 2 and 3 (each within the scatter of the next).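

In this assay the exchange at this aromatic carbon gives a 14-fold higher number from compound 1 to compound 3 (1.14 log units; beyond the scatter), so this position can move the read-out well beyond the scatter. The step comes with no change in heavy-atom count, 9 in each group, and each group keeps one six-membered aromatic ring of carbon only; the entering group adds 2 hydrogen-bond acceptors. No measurement at hand accounts for the step.

The compounds shown leave open whether the step follows the linking oxygen or the methoxy group. An unsubstituted phenoxy and a 3-methoxybenzyl at this carbon would separate the two.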